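The compounds below may be only part of what the source reports. "The series", "measured", "known", "first", "only" and "open" are said of these compounds alone.

Measured compounds in an assay on isolated protein for inhibition of NAD kinase (Homo sapiens), read by HPLC; on this read-out higher numbers stand for weaker inhibition and lower numbers for stronger inhibition:
- compound 1 `C[C@@]1(O)[C@@H](CSSC[C@H]2O[C@@H](n3cnc4c(N)ncnc43)[C@H](O)[C@]2(C)O)O[C@@H](n2cnc3c(N)ncnc32)[C@@H]1O` — compound 1 gives "not active" (no number reported)
- compound 2 `Nc1ncnc2c1nc(Br)n2[C@@H]1O[C@H](CSSC[C@H]2O[C@@H](n3c(Br)nc4c(N)ncnc43)[C@H](O)[C@@H]2O)[C@@H](O)[C@H]1O` — compound 2 gives 6000 nM
- compound 3 `C[C@@]1(O)[C@H](O)[C@@H](CSSC[C@H]2O[C@@H](n3cnc4c(N)ncnc43)[C@](C)(O)[C@@H]2O)O[C@H]1n1cnc2c(N)ncnc21` — compound 3 gives 280000 nM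

Compound 2 holds the lowest number of the two that were reported; the nearest is compound 3, whose value is far beyond the scatter, and compound 1 is reported without a number. For the measured compounds named here, no two measured compounds differ in one place only, so no single step is available to read off directly, and compound 1 and compound 3 each carry methyl groups on the sugar that compound 2 does not, which keeps their comparison with compound 2 loose.

Compound 4 `Nc1ncnc2c1ncn2[C@@H]1O[C@H](CSSC[C@H]2O[C@@H](n3c(Br)nc4c(N)ncnc43)[C@H](O)[C@@H]2O)[C@@H](O)[C@H]1O` has not been measured. Its difference from compound 2 is hydrogen in place of bromo on an aromatic carbon — hydrogen in place of bromo on an aromatic carbon, on one of the two bases only, the other base keeping its bromo. Among the reported values, the compound with both bromo groups sits lowest; whether one bromo alone keeps that behaviour is unknown. The expectation for the step from compound 2 to compound 4 in this assay is a rise, a 3.3-fold higher number from compound 2 to compound 4 (0.52 log units; beyond the scatter), of modest size. Compound 4 is therefore estimated at 20000 nM, within 6000 nM to 80000 nM.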

Compound 4, half-maximal inhibitory concentration: 6000 nM
Beside the measured number, compound 4's estimate is 3.3-fold (0.52 log units) above it; the measured number falls inside the stated range.
By their numbers in this assay, from the lowest: compounds 2 and 4 (each within the scatter of the next); then compound 3.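

Working notes on the series. In this assay, for the compounds shown here, hydrogen in place of bromo on an aromatic carbon, on one of the two bases only, gives no change at the digits printed from compound 2 to compound 4 (within the scatter); this is the first step that changes one place alone. The position in question lies on the five-membered aromatic ring with 2 nitrogen, between two ring nitrogen atoms, and with the other base keeping its bromo, the bromo at this position can be exchanged for hydrogen with no change in the number beyond the usual scatter, so having bromo on both bases is not required to hold the level of compound 2. No independent measurement is available to explain why the number holds at this position.

The role of the remaining bromo stays open, as no step among the compounds shown changes it, so it cannot be said whether one bromo on either base is what holds the level of compound 4. Equally open, as far as these compounds go, is whether this aromatic carbon tolerates anything larger or different in kind, such as an amine or a longer chain, as well as it tolerates hydrogen and bromo.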